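Ring Size of the Basic Amine in Flavone Antiproliferatives

The source may hold more compounds than are shown below. What is called first, only, known or untested is meant among the compounds shown, and "the series" means these compounds.

The measured compounds, in a functional assay on BCG823 cells (Homo sapiens) for antiproliferative activity, read by MTT assay, with a stated time of 48 h; a lower number here means a stronger inhibitor, a higher number a weaker inhibitor:
compound 1 `O=c1cc(-c2ccccc2)oc2cc(OCc3ccccc3)c(OCCCCN3CCCCC3)c(O)c12` gives 3000 nM.
compound 2 `O=c1cc(-c2ccccc2)oc2cc(OCc3ccccc3)c(OCCCN3CCCC3)c(O)c12` gives > 100000 nM.
compound 3 `COc1cc2oc(-c3ccccc3)cc(=O)c2c(O)c1OCCCCN1CCCCC1` gives 21900 nM.

For compound 2 the reading is a limit of this assay and not a number.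

Compound 1 and compound 3 stand on related cores; the difference between them is hydrogen in place of phenyl on a saturated chain carbon bound to an oxygen on an aromatic ring, and the step of a 7.3-fold higher number from compound 1 to compound 3 (0.86 log units; beyond the scatter). Compound 3 thus holds the higher of the two numbers in this assay.

Within the core of compound 1, the change pyrrolidin-1-yl in place of (piperidin-1-yl)methyl on a saturated chain carbon, three bonds along the chain from an oxygen on an aromatic ring produces an at least 33-fold higher number from compound 1 to compound 2 (1.52 log units; beyond the scatter), with compound 2 reaching (the limit of > 100000 nM in this assay, at which 1 of the 3 values shown sits).

Compound 4 `COc1cc2oc(-c3ccccc3)cc(=O)c2c(O)c1OCCCN1CCCC1` is the partner of compound 3 carrying exactly this change, (pyrrolidin-1-yl in place of (piperidin-1-yl)methyl on a saturated chain carbon, three bonds along the chain from an oxygen on an aromatic ring), made at the same place as before. Because the step of an at least 33-fold higher number from compound 1 to compound 2 (1.52 log units; beyond the scatter) was large and ran to a limit, the step of a 14-fold higher number from compound 3 to compound 4 (1.14 log units; beyond the scatter) is expected to be of comparable size, and it starts from a weaker compound. Compound 4 is therefore estimated at about 300000 nM in this assay, between 60000 nM and 2000000 nM, most probably reported only as a limit.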

Compound 4, half-maximal inhibitory concentration: 6500 nM
The estimate for compound 4 lay 46-fold (1.66 log units) above the measured number; measured number below the stated range.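

In this assay the change from 4-(piperidin-1-yl)butyl to 3-(pyrrolidin-1-yl)propyl did not carry over from one core to the other, since on the core of compound 3 it gave a 3.4-fold lower number from compound 3 to compound 4 (0.53 log units; beyond the scatter), opposite in direction to the earlier step: the same change on two cores in this assay, an at least 33-fold higher number (1.52 log units; beyond the scatter) from compound 1 to compound 2 and a 3.4-fold lower number (0.53 log units; beyond the scatter) from compound 3 to compound 4, at least 110-fold (2.05 log units) apart, beyond the scatter of two such steps. The change of phenyl to hydrogen on the saturated chain carbon bound to an oxygen on an aromatic ring reversed as well, giving an at least 15-fold lower number from compound 2 to compound 4 (1.18 log units; beyond the scatter): the same change on two cores in this assay, a 7.3-fold higher number (0.86 log units; beyond the scatter) from compound 1 to compound 3 and an at least 15-fold lower number (1.18 log units; beyond the scatter) from compound 2 to compound 4, at least 110-fold (2.05 log units) apart, beyond the scatter of two such steps. Among the compounds shown here, the reading of compound 2, > 100000 nM, is a limit and not a number, and the four compounds show only that neither change transfers between these two cores, not why, nor how either would run on a further core.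

Ring size and chain length change together in every pair, which leaves open how a 3-(piperidin-1-yl)propyl or a 4-(pyrrolidin-1-yl)butyl chain would read on either core. Also open, going by these compounds, is how a morpholine ring or a dimethylamino group at the chain end would read in this assay.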